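Swapping chloro for fluoro in compound 3

This account rests on a few compounds, and the source may have more. Where it says the series, first, only, none or still open, it means among the compounds named here.

Measured in a functional assay on HepG2 cells (Homo sapiens) for antiproliferative activity, read by MTT assay, with a stated time of 48 h; on this read-out lower numbers stand for stronger inhibition and higher numbers for weaker inhibition:
- compound 1 `COc1ccc(C2OC(c3ccc4ccccc4c3)=NN2C(C)=O)cc1`: 3.6 ug/mL
- compound 2 `CC(=O)N1N=C(c2ccc3ccccc3c2)OC1c1ccccc1Br`: 3.98 ug/mL
- compound 3 `CC(=O)N1N=C(c2ccc3ccccc3c2)OC1c1ccccc1Cl`: 4.32 ug/mL

These three numbers cannot be told apart. Compound 3 lies within the usual scatter of both others, with a 1.1-fold higher number from compound 2 to compound 3 (0.04 log units; within the scatter) and a 1.2-fold higher number from compound 1 to compound 3 (0.08 log units; within the scatter).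

The untested compound 4 `CC(=O)N1N=C(c2ccc3ccccc3c2)OC1c1ccccc1F` has fluoro in place of chloro on an aromatic carbon, ortho to a large group: fluoro in place of chloro on an aromatic carbon.

The closest measured change is chloro in place of bromo on an aromatic carbon, which gave a 1.1-fold higher number from compound 2 to compound 3 (0.04 log units; within the scatter). A much larger swap, 2-bromophenyl in place of 4-methoxyphenyl on a saturated ring carbon, gave only a 1.1-fold higher number from compound 1 to compound 2 (0.04 log units; within the scatter). Both steps stay within the scatter, so no step beyond the scatter is expected in this assay for this smaller change. The estimated step is a 1.0-fold lower number from compound 3 to compound 4 (0.01 log units; within the scatter). For compound 4 the expected value is 4.2 ug/mL, with an estimated range of 2.4 ug/mL to 7.4 ug/mL.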

Compound 4, half-maximal inhibitory concentration: 3.36 ug/mL
Beside the measured number, compound 4's estimate is 1.3-fold (0.10 log units) above it, and the stated range covers the measured number.
By their numbers in this assay, from the lowest: compounds 4, 1, 2 and 3 (each within the scatter of the next).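

In this assay, within the data shown here, the earlier compounds carried only chloro or bromo on this aromatic carbon, ortho to a large group, and fluoro now joins them without a change that can be told from the scatter: replacing chloro gives a 1.3-fold lower number from compound 3 to compound 4 (0.11 log units; within the scatter), and replacing bromo gives a 1.2-fold lower number from compound 2 to compound 4 (0.07 log units; within the scatter). The wider swap to 2-fluorophenyl in place of 4-methoxyphenyl gives a 1.1-fold lower number from compound 1 to compound 4 (0.03 log units; within the scatter), so all four compounds remain within the scatter of one another. No measurement at hand explains why these swaps leave the number so little changed.

As far as these compounds go, the compounds with a group at this position carry only halogens there, so the effect of an amine, a carboxylic acid or a longer chain in that place remains open. Also open, from the compounds shown here alone, is how the number responds to changes elsewhere in the shared core, which is the same in all four compounds.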